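Working notes on liver microsome half-life, compound 2 to compound 3

A few compounds are considered here, and "the series" means these few. Any claim that something is new, unique, unknown or untested is made for them only; others in the source may bear on it.

Measured so far:
compound 1, `COc1nc2ccc(Br)cc2cc1[C@@H](c1ccnc(OC)c1OC)[C@@](O)(CCN(C)C)c1cccc(OC(F)F)c1`: 1.02 h
compound 2, `CCSc1ccc([C@H](c2cc3cc(Br)ccc3nc2OC)[C@@](O)(CCN(C)C)c2cccc(F)c2)cn1`: 1.07 h

In an ADME assay on microsomes from liver (Homo sapiens) for metabolic stability (a higher number here means that the compound lasts longer, a lower number that the compound disappears faster), compound 1 gives 1.02 h and compound 2 gives 1.07 h. The two numbers sit within the scatter of each other, so compound 2 is not set apart from compound 1 on this assay.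

Compound 3, `COc1nc2ccc(Br)cc2cc1[C@@H](c1cncc(C)c1)[C@@](O)(CCN(C)C)c1cccc(F)c1`, carries the change (5-methylpyridin-3-yl in place of 6-(ethylsulfanyl)pyridin-3-yl on a saturated chain carbon bound to an aromatic carbon and a saturated chain carbon). For the measured compounds named here, no measured pair shows the effect of this change in this assay, so nothing here predicts a shift in either direction. The step from compound 2 to compound 3 is expected to stay within the scatter, at a 1.0-fold higher number from compound 2 to compound 3 (0.01 log units; within the scatter). Compound 3 is therefore estimated at 1.1 h, with a range from 0.55 h to 2.2 h.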

Compound 3, half-life: 0.2 h
Compound 3: the middle estimate sits 5.5-fold (0.74 log units) above what was measured, outside the stated range (below it).
By their numbers in this assay, from the lowest: compound 3; then compounds 1 and 2 (each within the scatter of the next).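

In this assay placing 5-methylpyridin-3-yl where 6-(ethylsulfanyl)pyridin-3-yl stood on a saturated chain carbon bound to an aromatic carbon and a saturated chain carbon gives a 5.4-fold lower number from compound 2 to compound 3 (0.73 log units; beyond the scatter) on this single pair. For the compounds shown here, the earlier compounds offered no pair for this position, and this is the first sign that the group on this carbon can move the half-life. Nothing at hand bears on the reason for the shorter half-life.

The loss of ethylsulfanyl and the arrival of methyl come together here, so neither can be credited alone. From the compounds shown here alone, how a methylsulfanyl group or an amine on the pyridine would fare remains open.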